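From 4-fluorophenyl to 4-chlorophenyl on the sulfonyl group

A few compounds are considered here, and "the series" means these few. Any claim that something is new, unique, unknown or untested is made for them only; others in the source may bear on it.

Among the measured compounds shown here, in a functional assay on HeLa cells (Homo sapiens) for antiproliferative activity, read by MTT assay, with a stated time of 24 h (a higher number here means a weaker inhibitor, a lower number a stronger inhibitor), compound 1 (`Cc1ccc(C)c(S(=O)(=O)n2c(-c3cn(-c4ccccc4)nc3-c3ccc(F)cc3)nc3ccccc32)c1`) gives 320 nM and compound 2 (`O=S(=O)(c1ccc(F)cc1)n1c(-c2cn(-c3ccccc3)nc2-c2ccc(F)cc2)nc2ccccc21`) gives 2440 nM as the higher of the only two numbers so far. Compound 3 (`O=S(=O)(c1ccc(Cl)cc1)n1c(-c2cn(-c3ccccc3)nc2-c2ccc(F)cc2)nc2ccccc21`) is still unmeasured and differs from compound 2 at a single place: chloro in place of fluoro on an aromatic carbon. This is chloro in place of fluoro on an aromatic carbon, para to a large group, which turns 4-fluorophenyl into 4-chlorophenyl. For the measured compounds named here, one measured step bears on this change, and only loosely. Replacing 2,5-dimethylphenyl with 4-fluorophenyl on the sulfonyl sulfur gave a 7.6-fold higher number from compound 1 to compound 2 (0.88 log units; beyond the scatter) and shows that this group can matter. Going by the values given here, that exchange is much larger than the swap of one halogen for another, and no measured pair tests such a swap directly. A far smaller effect is therefore expected, with a slight lean towards a lower number. In this assay the estimated outcome is a 1.6-fold lower number from compound 2 to compound 3 (0.21 log units; within the scatter) and thus no expected shift beyond the scatter. For compound 3 the expected value is 1500 nM with an estimated range from 500 nM to 4000 nM as the likely span.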

Compound 3, half-maximal inhibitory concentration: 3450 nM
For compound 3 the middle estimate is 2.3-fold (0.36 log units) below the measured one; low and high end bracket the measured number.
By their numbers in this assay, from the lowest: compound 1; then compounds 2 and 3 (each within the scatter of the next).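

Exchanging 4-fluorophenyl for 4-chlorophenyl on the sulfonyl group gives a 1.4-fold higher number from compound 2 to compound 3 (0.15 log units; within the scatter) in this assay, so these two halogens are not told apart at this position. The gap to the 2,5-dimethylphenyl group, until now resting on the single step of a 7.6-fold higher number from compound 1 to compound 2 (0.88 log units; beyond the scatter), is seen again as an 11-fold higher number from compound 1 to compound 3 (1.03 log units; beyond the scatter), and at this position the choice between 2,5-dimethylphenyl and a halogen-bearing phenyl counts for far more than the choice of halogen among the three compounds shown. No measurement on hand accounts for any of these numbers.

Still open, from the compounds shown here alone, is whether the lower number of compound 1 needs both methyl groups or would survive with a single methyl group, and whether a methoxy group, an amine or a carboxylic acid on this phenyl ring would fall with compound 1 or with the two halogen-bearing compounds. The shared core is also unvaried here, so nothing shows whether the pattern at the sulfonyl group holds once the rest of the molecule changes.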